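A few compounds are considered here, and "the series" means these few. Any claim that something is new, unique, unknown or untested is made for them only; others in the source may bear on it.

Measured so far in a functional assay on COLO 205 cells (Homo sapiens) for inhibition, read by sulforhodamine B assay, with a stated time of 48 h, tested at 50 uM; on this read-out higher numbers stand for more inhibition of growth at the one concentration tested and lower numbers for less inhibition of growth:
- compound 1 `COc1ccc(/C=C/C(=O)/C=C/c2ccc(OCc3cn(CCCCOc4cc(=O)oc5ccccc45)nn3)c(OC)c2)cc1OC`: 53%
- compound 2 `COc1ccc(/C=C/C(=O)/C=C/c2ccc(OCc3cn(CCCCCOc4cc(=O)oc5ccccc45)nn3)c(OC)c2)cc1OC`: 43%
- compound 3 `COc1cc(/C=C/C(=O)/C=C/c2cccs2)ccc1OCc1cn(CCOc2cc(=O)oc3ccccc23)nn1`: 66%

On these numbers compound 2 cannot be separated from compound 1, since the two lie within the scatter of each other. Compound 3 reads higher than compound 2 by a gap beyond the scatter.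

The next entry is compound 4 `COc1cc(/C=C/C(=O)/C=C/c2cccs2)ccc1OCc1cn(CCCCCOc2cc(=O)oc3ccccc23)nn1`, still unmeasured. Its difference from compound 2 is thiophen-2-yl in place of 3,4-dimethoxyphenyl on a double-bonded chain carbon bound to a double-bonded chain carbon, with thiophen-2-yl in place of 3,4-dimethoxyphenyl on a double-bonded chain carbon bound to a double-bonded chain carbon.

Among the compounds with values here, no pair of measured compounds differs in one place only, so the size of this change has not been observed directly. Within the data shown here, the only guide is compound 3 at 66% as the sole reading with thiophen-2-yl, and that compound also differs from compound 4 in its chain, so the guide is partial. In this assay a modest rise is therefore expected, about the size of the scatter and possibly no more than that. The estimated move is a number 9 percentage points higher from compound 2 to compound 4 (within the scatter), upward. For compound 4 the expected value is 52%, within an estimated range of 38% to 68% for now.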

Compound 4, percent growth inhibition at one concentration: 30%
Compound 4: the middle estimate sits 22 percentage points above what was measured; measured number outside the range, below it.
By their numbers in this assay, from the lowest: compound 4; then compounds 2 and 1 (each within the scatter of the next); then compound 3.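

In this assay, within the data shown here, this is the first direct reading of a change at this place, on a double-bonded chain carbon bound to a double-bonded chain carbon: replacing 3,4-dimethoxyphenyl with thiophen-2-yl gives a number 13 percentage points lower from compound 2 to compound 4 (beyond the scatter), a modest loss of growth inhibition on the chain shared by this pair. The thiophen-2-yl group therefore does not by itself bring a high reading, as compound 3 gives 66% and compound 4, which differs from it only in the chain, gives 30%. Nothing at hand accounts for either difference, so the change can be described here but not explained.

The direction of this change rests on a single pair, so it remains open whether the same replacement would lower the reading on the chain of compound 3, where the 3,4-dimethoxyphenyl partner is missing from the compounds shown. Also open, going by these compounds, is how a furan-2-yl or plain phenyl group at this place, or a chain longer than that of compound 4, would read at the one concentration tested.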